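The source may hold more compounds than are shown below. What is called first, only, known or untested is meant among the compounds shown, and "the series" means these compounds.

Compound 1 (`Cc1ccc(-c2cnc(NC(=O)c3ccc(F)cc3)n2C)cc1`): 60000 nM
Compound 2 (`Cn1c(-c2ccccc2[N+](=O)[O-])cnc1NC(=O)c1ccc(F)cc1`): 31000 nM
Compound 3 (`COc1ccccc1-c1cnc(NC(=O)c2ncc[nH]2)n1C`): > 50000 nM

In a toxicity assay on THP-1 cells (Homo sapiens) for inhibition (a higher number here means that more compound is tolerated, a lower number that less compound is tolerated), compound 3 reads > 50000 nM as a limit of the assay and not a number. Compound 4 (`COc1ccccc1-c1cnc(NC(=O)c2ccc(F)cc2)n1C`) differs from compound 3 by having 4-fluorophenyl in place of 1H-imidazol-2-yl on a carbonyl carbon. Among the compounds with values here, no measured pair shows this change alone. Compound 1 (60000 nM) and compound 2 (31000 nM) both carry 4-fluorophenyl on a carbonyl carbon, and their two values lie within the scatter of each other. On those values, no step beyond the scatter is expected in this assay for this change. The expected step is small (an at least 1.2-fold lower number from compound 3 to compound 4 (0.09 log units; that floor lies within the scatter)). For compound 4 the estimate is 40000 nM with 15000 nM to 80000 nM as its expected range.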

Compound 4, half-maximal cytotoxic concentration: > 100000 nM
Compound 4 ended at the assay's limit (the forecaster's own chance of this, stated with the estimate: 35%); middle value at least 2.5-fold (0.39 log units) from the limit.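

In this assay, methoxy in place of nitro on an aromatic carbon gives an at least 3.2-fold higher number from compound 2 to compound 4 (0.50 log units; beyond the scatter), so the group at this place can move the tolerated concentration beyond the scatter. With 2-methoxyphenyl in place of 4-methylphenyl on an aromatic carbon, the result is an at least 1.6-fold higher number from compound 1 to compound 4 (0.22 log units; that floor lies within the scatter). Compound 3 and compound 4 both stand as limits of the assay, and the step between them cannot be read. Still open, as far as these compounds go, is how large the change from 1H-imidazol-2-yl to 4-fluorophenyl on a carbonyl carbon really is, and how an amine in place of methoxy on that aromatic carbon would read.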